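The compounds below may be only part of what the source reports. "The series", "measured", "known", "first", "only" and "open" are said of these compounds alone.

Measured compounds:
compound 1 `CC(=O)OC[C@H]1O[C@H](OC[C@H](Cn2cc(COc3ccc(-c4noc(NC5CCCCC5)n4)cc3)nn2)OC(C)=O)C=C[C@@H]1OC(C)=O`, 99.5 ug/mL
compound 2 `CC(=O)OC[C@H]1O[C@H](OC[C@@H](Cn2cc(CN(c3nc(-c4ccc(F)cc4)no3)C3CCCCC3)nn2)OC(C)=O)C=C[C@@H]1OC(C)=O`, 28.8 ug/mL
compound 3 `C#CCN(c1nc(-c2ccc(Cl)cc2)no1)C1CCCCC1`, 41.3 ug/mL

The read-out is an ADME assay on HepG2 cells (Homo sapiens) for cytotoxicity, read by MTT assay, with a stated time of 48 h; a higher number here means that more compound is tolerated, a lower number that less compound is tolerated. In this assay compound 2 gives 28.8 ug/mL and sits at the low end of the three numbers. Compound 3 gives 41.3 ug/mL, which is within the usual scatter of compound 2, so no order between the two is claimed. Compound 1 gives 99.5 ug/mL, and that gap to compound 2 lies beyond the scatter, so compound 1 is tolerated at a higher concentration.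

Compound 4 `CC(=O)OC[C@H]1O[C@H](OC[C@@H](Cn2cc(CN(c3nc(-c4ccccc4)no3)C3CCCCC3)nn2)OC(C)=O)C=C[C@@H]1OC(C)=O` is not yet measured. It differs from compound 2 in one place: hydrogen in place of fluoro on an aromatic carbon. Among the measured compounds shown here, no step between measured compounds with this change is available, so the expectation rests on the size of the change alone, a single heavy atom removed at the edge of the molecule with the rest unchanged. The step from compound 2 to compound 4 is expected to be small and, as a 1.2-fold higher number from compound 2 to compound 4 (0.08 log units; within the scatter), not beyond the scatter in either direction. For compound 4 in this assay the estimate is 35 ug/mL, with a range from 15 ug/mL to 80 ug/mL.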

Compound 4, half-maximal cytotoxic concentration: 19.9 ug/mL
Compound 4: the middle estimate sits 1.8-fold (0.25 log units) above what was measured; measured number inside the range.
By their numbers in this assay, from the lowest: compounds 4, 2 and 3 (each within the scatter of the next, the first and the last beyond it); then compound 1.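

In this assay, hydrogen in place of fluoro on an aromatic carbon, para to a large group, gives a 1.4-fold lower number from compound 2 to compound 4 (0.16 log units; within the scatter). Among the compounds shown here, this is the only single-place step so far, and it shows that at this position the change from 4-fluorophenyl to phenyl sets no order between the two compounds. No measurement shown bears on the reason for this step.

Still open, as far as these compounds go, is whether a different group at this position, such as methoxy, an amine or a carboxylic acid, would produce a step beyond the scatter. Compound 1 differs from the other compounds in more than one place, so its higher number cannot be assigned to any single structural difference.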